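Trimming the aryl group down to methyl

This account rests on a few compounds, and the source may have more. Where it says the series, first, only, none or still open, it means among the compounds named here.

In a functional assay on AGS cells (Homo sapiens) for cytotoxicity, read by MTT assay, with a stated time of 48 h (a lower number here means a stronger inhibitor, a higher number a weaker inhibitor), compound 1 `Cc1nc2c3ccccc3ccc2c2nc3c(ccc4ccccc43)c(-c3cccc4ccccc34)c12` gives 12100 nM. Compound 2 `Cc1ccc(-c2c3ccc4ccccc4c3nc3c2c(C)nc2c4ccccc4ccc32)cc1` reaches only the limit of > 80000 nM in this assay, so it stands at the weak end of what was measured. Among the compounds with values here, the one measured step, an at least 6.6-fold higher number from compound 1 to compound 2 (0.82 log units; beyond the scatter), already went toward a smaller group on that carbon. Compound 3 `Cc1nc2c3ccccc3ccc2c2nc3c(ccc4ccccc43)c(C)c12` carries the change (methyl in place of 4-methylphenyl on an aromatic carbon), shrinking the group further. With compound 2 sitting at the limit (the limit of > 80000 nM in this assay, at which 1 of the 2 values shown sits), the expected step that the limit leaves unreadable from compound 2 to compound 3 is likely none that can be seen. Compound 3 is therefore estimated at 100000 nM, within 30000 nM to 300000 nM.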

Compound 3, half-maximal inhibitory concentration: > 80000 nM
Compound 3 gave a limit, no number; the forecaster's own chance of this, stated with the estimate: 70%; the middle value is on the limit's open side.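

Replacing naphthalen-1-yl with methyl on this aromatic carbon gives an at least 6.6-fold higher number from compound 1 to compound 3 (0.82 log units; beyond the scatter) in this assay. Compound 1 therefore remains the only one of the three with a number, and both a one-ring aryl group and a single carbon end at the limit. The step between compound 2 and compound 3 cannot be read, since each value is a limit: the limit of > 80000 nM in this assay, at which 2 of the 3 values shown sit.

Where compound 2 and compound 3 truly lie, and so how 4-methylphenyl and methyl rank, stays open. So does whether an amine or a carboxylic acid on this carbon would give a measurable value.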